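Chloro to methyl on the aryl ring of compound 1

The compounds below may be only part of what the source reports. "The series", "measured", "known", "first", "only" and "open" are said of these compounds alone.

Compound 1 `Cc1oc(-c2ccc(Cl)cc2)nc1CN1CCC(C(=O)NCCCN2C[C@H](C)C[C@H](C)C2)CC1` gives 11500 nM in an ADME assay on Huh7.5.1 cells (Homo sapiens) for cytotoxicity, read by ATP content, with a stated time of 48 h (on this read-out higher numbers stand for lower toxicity in this test and lower numbers for higher toxicity in this test), the lowest of the three numbers measured. Compound 2 `Cc1ccccc1-c1nc(CN2CCC(C(=O)NCCCN3CCC(C)CC3)CC2)c(C)o1` gives 12300 nM in this assay, within the scatter of compound 1. Among the compounds with values here, compound 3 `Cc1ccccc1-c1nc(CN2CCC(C(=O)N3CCN(CCN(C)C)CC3)CC2)c(C)o1` gives 27200 nM in this assay, the only value beyond the scatter of compound 1. Within the data shown here, the one measured step, a 2.2-fold higher number from compound 2 to compound 3 (0.34 log units; beyond the scatter), concerns a change on the carbonyl carbon and does not touch the aryl ring. Compound 4 `Cc1ccc(-c2nc(CN3CCC(C(=O)NCCCN4C[C@H](C)C[C@H](C)C4)CC3)c(C)o2)cc1` differs from compound 1 by methyl in place of chloro on an aromatic carbon. Among the measured compounds shown here, no measured step bears on this change, so no step beyond the scatter in this assay is expected in either direction. Compound 4 is therefore estimated at 12000 nM, with a range of 6000 nM to 25000 nM, the expected step being a 1.0-fold higher number from compound 1 to compound 4 (0.02 log units; within the scatter).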

Compound 4, half-maximal cytotoxic concentration: 4330 nM
For compound 4 the middle estimate is 2.8-fold (0.44 log units) above the measured one; the whole stated range lies above it.
By their numbers in this assay, from the lowest: compound 4; then compounds 1 and 2 (each within the scatter of the next); then compound 3.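

In this assay, methyl in place of chloro gives a 2.7-fold lower number from compound 1 to compound 4 (0.42 log units; beyond the scatter) and so leaves the lowest number in the series. This position, para to a large group, therefore responds to the exchange of a single heavy atom, which the earlier step on the carbonyl carbon could not show. Nothing measured here accounts for the difference between chloro and methyl. As far as these compounds go, whether fluoro, methoxy or plain hydrogen at this position would fall with chloro or with methyl remains open, as does whether the step carries over to the amide side of compound 3.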